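The source may report more compounds than this note shows. Statements on the series, on what has been measured and on what is new or still open speak of the compounds shown alone.

Three compounds share a core bearing an acetic acid chain and an ether-linked five-membered heteroaromatic ring, and all three have been tested in a functional assay on CHO cells for agonist activity at Free fatty acid receptor 1 (Homo sapiens), read by FLIPR and calcium flux, tested at 100 nM; a lower number here means a weaker effect, a higher number a stronger effect of the compound at the concentration tested. Compound 1, `O=C(O)CC1COc2cc(OCc3nnc(-c4ccccc4)s3)ccc21`, gives 3.36% in this assay. Compound 2, `O=C(O)CC1COc2cc(OCc3ncc(-c4ccccc4)s3)ccc21`, gives 5.26%. Compound 3, `Cc1nc(-c2cccs2)sc1COc1ccc2c(c1)OCC2CC(=O)O`, gives 35.2%, the highest of the three numbers; its gap to compound 2 and its gap to compound 1 both lie beyond the usual scatter, so compound 3 stands clearly apart from the other two.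

The next compound, compound 4, is `COc1ccc(-c2nc(C)c(COc3ccc4c(c3)OCC4CC(=O)O)s2)cc1`. Compared with compound 3 the change is 4-methoxyphenyl in place of thiophen-2-yl on an aromatic carbon. Within the data shown here, no pair of measured compounds differs in exactly this way, so there is no measured step to lean on; the only guidance is that compound 3, which carries the thiophen-2-yl, gives 35.2%, the strongest number seen so far. Compound 4 is therefore expected to stay in the region of compound 3, with a step of a number 4.8 percentage points higher from compound 3 to compound 4 (within the scatter) that may not exceed the scatter. The estimate for compound 4 in this assay is 40%, within a range from 15% to 70%.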

Compound 4, a percentage reported as activity, at one concentration (the size of the read-out at that concentration, not a potency): 46.8%
The estimate for compound 4 lay 6.8 percentage points below the measured number; measured number inside the range.
By their numbers in this assay, from the lowest: compounds 1 and 2 (each within the scatter of the next); then compound 3; then compound 4.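

In this assay, among these compounds, replacing thiophen-2-yl with 4-methoxyphenyl gives the first measured step between compounds that differ in one place, a number 11.6 percentage points higher from compound 3 to compound 4 (beyond the scatter). It shows that this aromatic carbon, next to the ring nitrogen and next to the ring sulfur, accepts a six-membered aromatic ring of carbon only, of 8 heavy atoms against 5, and that the effect at the tested concentration rises rather than falls. Nothing available here accounts for the rise.

The change swaps the ring and adds the methoxy group together, so the compounds shown leave open which of the two carries the step, and whether a 4-chlorophenyl or a pyridine ring on this carbon would do the same. No pair shown isolates the methyl group on the same ring either.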